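Swapping Chloro for Methoxy on a Shared Core

A few compounds are considered here, and "the series" means these few. Any claim that something is new, unique, unknown or untested is made for them only; others in the source may bear on it.

Of the compounds shown here, three have so far been tested in an ADME assay on HEK293 cells (Homo sapiens) for cytotoxicity, with a stated time of 6 h; a lower number here means that less compound is tolerated, a higher number that more compound is tolerated. Compound 1 (`CCCC(C)Nc1nc(N)nc2ccccc12`) gives > 25000 nM, which is a limit of the assay and not a number. Compound 2 (`CCCCNc1nc(N)nc2cc(CN(C)C)ccc12`) gives > 18000 nM, which is also a limit. Within the data shown here, compound 3 (`CCCCNc1nc(N)nc2cccc(Cl)c12`) gives 100 nM, the only true number among the three results.

Compound 4 (`CCCCNc1nc(N)nc2cccc(OC)c12`) differs from compound 3 in one place: methoxy in place of chloro on an aromatic carbon, (methoxy in place of chloro on an aromatic carbon). Among the measured compounds shown here, no two measured compounds differ in just one place, so no earlier step shows how large such a change tends to be. Any forecast for this assay is therefore rough. A shift toward more compound being tolerated is expected, though it could prove small. The expected change is a 15-fold higher number from compound 3 to compound 4 (1.18 log units; beyond the scatter). For compound 4 the estimated value is 1500 nM, with an expected range from 100 nM to 25000 nM.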

Compound 4, half-maximal cytotoxic concentration: > 25000 nM
Compound 4 was reported as a limit (the forecaster's own chance of this, stated with the estimate: 45%); at least 16-fold (1.22 log units) between middle value and limit.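

In this assay, among these compounds, this is the first pair of compounds that differ in one place, and methoxy in place of chloro on this aromatic carbon gives an at least 250-fold higher number from compound 3 to compound 4 (2.39 log units; beyond the scatter). Compound 4 gives > 25000 nM, which is a limit of the assay and not a number. The step therefore shows only the smallest possible size of the change, and the true gap may be wider, since compound 4 sits at the top limit shown: the limit of > 25000 nM in this assay, at which 2 of the 4 values shown sit.

One pair cannot show whether the low number of compound 3 belongs to chloro alone, or whether a fluoro, a methyl or an amine on this same carbon would give a similar result. It also leaves open whether the swap would have as large an effect on a shared core carrying a different side chain.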